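Methoxymethoxy in Place of Hydrogen: Expected Cytotoxicity of Compound 4

The source may report more compounds than this note shows. Statements on the series, on what has been measured and on what is new or still open speak of the compounds shown alone.

Three compounds built on one shared core have been measured in a functional assay on HCT-116 cells (Homo sapiens) for cytotoxicity, read by MTT assay, with a stated time of 48 h; on this read-out higher numbers stand for weaker inhibition and lower numbers for stronger inhibition:

compound 1 `O=C(/C=C/c1ccc2c(c1)B(O)OC2)c1ccccc1` gives 6100 nM
compound 2 `O=C(/C=C/c1ccc2c(c1)B(O)OC2)c1ccc(-c2ccccc2)cc1` gives 9500 nM
compound 3 `O=C(/C=C/c1ccc2c(c1)B(O)OC2)c1ccc([N+](=O)[O-])cc1` gives 9100 nM

Compound 1 stands at the lowest of the three numbers, but neither neighbour is separated from it by more than the scatter: the step of a 1.6-fold higher number from compound 1 to compound 2 (0.19 log units; within the scatter) and the step of a 1.5-fold higher number from compound 1 to compound 3 (0.17 log units; within the scatter) are both small, and the step of a 1.0-fold lower number from compound 2 to compound 3 (0.02 log units; within the scatter) is smaller still. The three compounds therefore cannot be ordered on this read-out.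

Compound 4 `COCOc1cccc(C(=O)/C=C/c2ccc3c(c2)B(O)OC3)c1` differs from compound 1 in one place: methoxymethoxy in place of hydrogen on an aromatic carbon. The two measured steps that bear on this change are those from compound 1 to compound 2 and from compound 1 to compound 3, each of which also exchanges a hydrogen on an aromatic carbon of that ring for a new group, and each of which stayed within the scatter. On that basis compound 4 is expected to show no step beyond the scatter in this assay, with the number, if anything, drifting slightly higher, as a step of a 1.2-fold higher number from compound 1 to compound 4 (0.09 log units; within the scatter). The estimate for compound 4 is therefore 7500 nM, expected to fall between 3500 nM and 16000 nM.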

Compound 4, half-maximal inhibitory concentration: 13300 nM
Compound 4: middle estimate off by 1.8-fold (0.25 log units), on the low side, within the range that was stated.
By their numbers in this assay, from the lowest: compounds 1, 3, 2 and 4 (each within the scatter of the next, the first and the last beyond it).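

In this assay, within the data shown here, methoxymethoxy on an aromatic carbon of the six-membered aromatic ring, meta to a large group, gives a 2.2-fold higher number from compound 1 to compound 4 (0.34 log units; beyond the scatter) and so produces the first step beyond the scatter seen from compound 1. The earlier exchanges of hydrogen on this ring, a 1.6-fold higher number from compound 1 to compound 2 (0.19 log units; within the scatter) and a 1.5-fold higher number from compound 1 to compound 3 (0.17 log units; within the scatter), did not separate from compound 1, so a new group on this ring can weaken inhibition measurably, although the effect here is modest and rests on this single compound. The data shown offer no measurement that accounts for this step, and its cause stays unknown.

From the compounds shown here alone, it remains open whether the step belongs to methoxymethoxy itself or to its place on the ring, a question that a hydroxyl, a methoxy group or an amine at the same place would help to settle. Going by these compounds, it is equally open how methoxymethoxy would behave on another carbon of this ring, and whether a longer chain at this place would move the number further from that of compound 1.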